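Amide in Place of Amine: Expectations for Compound 4

The source may report more compounds than this note shows. Statements on the series, on what has been measured and on what is new or still open speak of the compounds shown alone.

Four compounds share a bicyclic pyrazole core carrying an amide. Compound 1 `O=C(c1nn(-c2ccccc2)c2c1CC(NCc1ccccc1)CC2)N1CCCCC1` bears a phenyl on the pyrazole nitrogen and a benzylamine on the saturated ring, and in an assay on isolated protein for antagonist activity at Sigma intracellular receptor 2 (Homo sapiens), read by scintillation counting, with a stated time of 120 min, in the presence of a further agent that is not named here (on this read-out lower numbers stand for stronger inhibition and higher numbers for weaker inhibition), compound 1 gives 501 nM. Compound 2 `CCCn1nc(C(=O)N(C)C)c2c1CCC(OCc1ccc(F)cc1)C2` instead carries a propyl, a dimethylamide and an ether link to the 4-fluorobenzyl group; in this assay compound 2 reaches only the assay limit, > 10000 nM. Compound 3 `CCCn1nc(C(=O)N(C)C)c2c1CCC(NCc1ccc(F)cc1)C2` keeps the same propyl and dimethylamide but links the 4-fluorobenzyl through an amine nitrogen, and in this assay compound 3 gives 2000 nM. Of the two numbers reported, compound 3 has the higher one, and its gap to compound 1 lies beyond the usual scatter. Compound 4 `CCCn1nc(C(=O)N(C)C)c2c1CCC(NC(=O)c1ccc(F)cc1)C2` is not yet measured. It differs from compound 3 in one place: (4-fluorophenyl)carbonyl in place of 4-fluorobenzyl on an amine nitrogen. For the measured compounds named here, no measured step of this kind is available. Compound 2 shows that replacing that amine nitrogen with oxygen leaves only a limit, so for compound 4 a weakening beyond the scatter is expected, a 4.0-fold higher number from compound 3 to compound 4 (0.60 log units; beyond the scatter). The estimated value for compound 4 in this assay is 8000 nM, between 2500 nM and 30000 nM.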

Compound 4, inhibition constant: > 10000 nM
Compound 4 ended at the assay's limit; the forecaster's own chance of this, stated with the estimate: 40%; middle value at least 1.2-fold (0.09 log units) away from the limit.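

In this assay, compound 4 gives > 10000 nM, which is a limit of the assay and not a number. Placing (4-fluorophenyl)carbonyl in place of 4-fluorobenzyl on the amine nitrogen produces an at least 5.0-fold higher number from compound 3 to compound 4 (0.69 log units; beyond the scatter), so keeping the nitrogen is not enough to retain a measurable value here, whereas the earlier compounds had shown only the swap of that nitrogen for oxygen, in compound 2. The true size of this loss cannot be read, because the result sits at the top of what the assay reports: the limit of > 10000 nM in this assay, at which 2 of the 4 values shown sit.

The compounds shown leave open whether other groups on this amine nitrogen would restore or improve on the value of compound 3, for example a sulfonyl link in place of the carbonyl, a longer chain such as 2-(4-fluorophenyl)ethyl, or a methyl added to the nitrogen while the 4-fluorobenzyl stays. They also leave open whether the carbonyl would cost as much on the core of compound 1, which differs from compound 3 in several places and so offers no direct comparison.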